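The source may hold more compounds than are shown below. What is called first, only, known or untested is meant among the compounds shown, and "the series" means these compounds.

Compound 1 `COc1ccc(Nc2nc(N)nc(CSc3nnc(-c4ccccc4)n3/N=C/c3ccccc3)n2)cc1` and compound 2 `Cc1ccccc1Nc1nc(N)nc(CSc2nnc(-c3ccccc3)n2/N=C/c2ccc(Br)cc2)n1` share one core. In an ADME assay on Vero cells (Chlorocebus sabaeus) for cytotoxicity, read by resazurin assay, with a stated time of 3 days (a higher number here means that more compound is tolerated, a lower number that less compound is tolerated), compound 1 gives 1500 ug/mL. In this assay compound 2 gives 1500 ug/mL, level with compound 1 within the scatter. Compound 3 `Cc1ccccc1Nc1nc(N)nc(CSc2nnc(-c3ccccc3)n2/N=C/c2ccccc2)n1` differs from compound 2 in one place: hydrogen in place of bromo on an aromatic carbon. Within the data shown here, no measured pair shows this change, so its effect is unknown. Compound 2 gives 1500 ug/mL and the change removes only the bromine. The step of no change at the digits printed from compound 2 to compound 3 (within the scatter) is therefore expected to stay within the scatter. Compound 3 is estimated at 1500 ug/mL, ranging from 700 ug/mL to 2500 ug/mL.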

Compound 3, half-maximal cytotoxic concentration: 1250 ug/mL
Estimate against measurement, compound 3: 1.2-fold (0.08 log units) above; measured number inside the range.
By their numbers in this assay, from the lowest: compounds 3, 1 and 2 (each within the scatter of the next).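

In this assay the change from 4-bromophenyl to phenyl gives a 1.2-fold lower number from compound 2 to compound 3 (0.08 log units; within the scatter) and so puts hydrogen level with bromo at this position on the aromatic ring. Placing 2-methylphenyl in place of 4-methoxyphenyl on the nitrogen gives a 1.2-fold lower number from compound 1 to compound 3 (0.08 log units; within the scatter) and also stays within the scatter. Nothing measured here offers an explanation for either step. Only bromo and hydrogen are shown at this position, so it remains open whether an amine or a carboxylic acid there would also read level.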